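Cyclohexyl for Isobutyl Beside the Amine

This account rests on a few compounds, and the source may have more. Where it says the series, first, only, none or still open, it means among the compounds named here.

Compound 1 `CC(C)CCCN(C(=O)[C@@H]1C[C@H]1c1ccccc1)c1ccc(-c2ccccc2)cc1`: in a functional assay for agonist activity at G protein-coupled receptor 88 (Homo sapiens), read by HTRF and cAMP accumulation (on this read-out lower numbers stand for an effect already at smaller amounts and higher numbers for an effect only at larger amounts of compound), compound 1 reaches only a limit, > 100 nM.
Compound 2 `CC(C)C[C@@H](N)CN(C(=O)[C@@H]1C[C@H]1c1ccccc1)c1ccc(-c2ccccc2)cc1`: in this assay compound 2 gives 1.8 nM.
Compound 3 `CN[C@@H](CC(C)C)CN(C(=O)[C@@H]1C[C@H]1c1ccccc1)c1ccc(-c2ccccc2)cc1`: in this assay compound 3 gives 2 nM.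

Compound 3 holds the higher of the two numbers, with compound 2 nearest at a 1.1-fold higher number from compound 2 to compound 3 (0.05 log units; within the scatter). For compound 1 only a limit is known, (the limit of > 100 nM in this assay, at which 1 of the 3 values shown sits). The amine on the chain carried the large gains, an at least 55-fold lower number from compound 1 to compound 2 (1.74 log units; beyond the scatter) and an at least 50-fold lower number from compound 1 to compound 3 (1.69 log units; beyond the scatter), while the methyl on that nitrogen made no difference, a 1.1-fold higher number from compound 2 to compound 3 (0.05 log units; within the scatter). Compound 4 `N[C@H](CN(C(=O)[C@@H]1C[C@H]1c1ccccc1)c1ccc(-c2ccccc2)cc1)C1CCCCC1` carries the change (amino(cyclohexyl)methyl in place of 3-methyl-1-(methylamino)butyl on a saturated chain carbon bound to an amide-type nitrogen). Among the measured compounds shown here, it keeps an amino group, as compound 2 does, and brings a six-membered ring in place of the branched chain; none of the measured steps tests that exchange, so the large amine effect is expected to remain and the ring is expected to move the number little beyond the scatter, in either direction. Compound 4 is therefore estimated at 3 nM, within 1 nM to 12 nM, an expected step of a 1.5-fold higher number from compound 3 to compound 4 (0.18 log units; within the scatter).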

Compound 4, half-maximal effective concentration: 0.66 nM
Compound 4: middle estimate off by 4.5-fold (0.66 log units), on the high side, and the stated range ends above it.
By their numbers in this assay, from the lowest: compound 4; then compounds 2 and 3 (each within the scatter of the next). At a limit, above all of these: compound 1.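

On a saturated chain carbon bound to an amide-type nitrogen, the ring-bearing amino(cyclohexyl)methyl group does more than preserve the effect of the amine: it gives a 2.7-fold lower number from compound 2 to compound 4 (0.44 log units; beyond the scatter), and, with the methyl on the nitrogen also gone, a 3.0-fold lower number from compound 3 to compound 4 (0.48 log units; beyond the scatter). The earlier compounds shown here varied only the amine and its methyl, whereas this change shows that the carbon group attached to the amine-bearing carbon can also shift the number beyond the scatter in this assay. The widest step, an at least 150-fold lower number from compound 1 to compound 4 (2.18 log units; beyond the scatter), rests on a limit for compound 1: the limit of > 100 nM in this assay, at which 1 of the 4 values shown sits.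

The compounds shown leave open whether a cyclopentyl or phenyl ring in place of the cyclohexyl ring would keep this gain. They also leave open whether a methylamino group on the cyclohexyl compound would again sit within the scatter of the plain amino group.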